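Halophenyl triazole swap carried onto a second core

The compounds below may be only part of what the source reports. "The series", "measured", "known", "first", "only" and "open" are said of these compounds alone.

Compound 1 `CC(C)=CCC/C(C)=C/CC/C(C)=C/CC[C@@H]1[C@@]2(C)CC/C(=N\OCc3cn(-c4ccc(Cl)cc4)nn3)C(C)(C)[C@@H]2CC[C@@]1(C)O` and compound 2 `CC(C)=CCC/C(C)=C/CC/C(C)=C/CC[C@@H]1[C@@]2(C)CC/C(=N\OCc3cn(-c4cccc(Br)c4)nn3)C(C)(C)[C@@H]2CC[C@@]1(C)O` share one core and differ only by 3-bromophenyl in place of 4-chlorophenyl on an aromatic nitrogen. Among the compounds with values here, in a functional assay on HepG2 cells (Homo sapiens) for cytotoxicity, read by MTT assay, with a stated time of 48 h (a lower number here means a stronger inhibitor, a higher number a weaker inhibitor), compound 1 gives 19900 nM, and compound 2 gives 39800 nM; the step of a 2.0-fold higher number from compound 1 to compound 2 (0.30 log units; within the scatter) is the only measured instance of this change. Compound 3 `CC(C)=CCC/C(C)=C/CC/C(C)=C/CC[C@@H]1[C@@]2(C)C/C(=C\c3ccc(OCc4cn(-c5ccc(Cl)cc5)nn4)cc3)C(=O)C(C)(C)[C@@H]2CC[C@@]1(C)O` carries the same 1-(4-chlorophenyl)-1H-1,2,3-triazol-4-yl group on a different core; the difference between the two cores is not broken down here. In this assay compound 3 gives 123000 nM, the highest of the three numbers and beyond the scatter from both compound 1 and compound 2. Compound 4 `CC(C)=CCC/C(C)=C/CC/C(C)=C/CC[C@@H]1[C@@]2(C)C/C(=C\c3ccc(OCc4cn(-c5cccc(Br)c5)nn4)cc3)C(=O)C(C)(C)[C@@H]2CC[C@@]1(C)O` is compound 3 with 3-bromophenyl in place of 4-chlorophenyl on an aromatic nitrogen, the same change as from compound 1 to compound 2, at the same place. The step from compound 3 to compound 4 is expected to be a 1.6-fold higher number from compound 3 to compound 4 (0.21 log units; within the scatter), set beside the earlier step because a 2.0-fold higher number from compound 1 to compound 2 (0.30 log units; within the scatter) lay within the scatter. Compound 4 is accordingly expected to give about 200000 nM in this assay, within 90000 nM to 450000 nM. Since compound 3 already stands high, the assay may also report only a limit for compound 4.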

Compound 4, half-maximal inhibitory concentration: 23700 nM
For compound 4 the middle estimate is 8.4-fold (0.93 log units) above the measured one; measured number below the stated range.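

In this assay the swap of 4-chlorophenyl for 3-bromophenyl on the aromatic nitrogen gives a 5.2-fold lower number from compound 3 to compound 4 (0.72 log units; beyond the scatter), a drop beyond the scatter, while the same swap on the core of compound 1 stays within the scatter. The step measured on one core therefore did not carry over to the other core, and the two steps differ: the same change on two cores in this assay, a 2.0-fold higher number (0.30 log units; within the scatter) from compound 1 to compound 2 and a 5.2-fold lower number (0.72 log units; beyond the scatter) from compound 3 to compound 4, 10-fold (1.02 log units) apart, beyond the scatter of two such steps. This rests on one pair per core and does not show which feature of the cores separates the two results; the swap also changes the halogen and its place on the phenyl ring together, and these two pairs do not tell those changes apart.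

Open, going by these compounds, is whether 3-chlorophenyl or 4-bromophenyl would track with compound 3 or with compound 4 on this core, which would separate the halogen from its place on the ring. Also open, on these data alone, is how an unsubstituted phenyl or a 3-methoxyphenyl group at the same nitrogen would read on each of the two cores.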